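Swapping a Nitrile for a Methyl on Two Cores

The compounds below may be only part of what the source reports. "The series", "measured", "known", "first", "only" and "open" are said of these compounds alone.

Compound 1 `Cc1cc(C#N)cc(C)c1Oc1ccnc(Nc2ccc(C#N)cc2)n1` carries a cyano group on one of its aromatic rings, and in a physicochemical assay for lipophilicity (on this read-out lower numbers stand for lower lipophilicity and higher numbers for higher lipophilicity), compound 1 gives 1.39. Compound 2 `Cc1cc(C)c(Oc2ccnc(Nc3ccc(C#N)cc3)n2)c(C)c1` is the same molecule with that cyano replaced: methyl in place of cyano on an aromatic carbon. In this assay compound 2 gives 1.82, so the change made a number 0.43 log units higher from compound 1 to compound 2 (beyond the scatter).

Compound 3 `Cc1cc(C#N)cc(C)c1Nc1nc(Nc2ccc(C#N)cc2)ncc1Cl` shares the cyano-bearing ring of compound 1 but sits on a different core; how the two cores differ is not broken down here. In this assay compound 3 gives 1.11. Compound 4 `Cc1cc(C)c(Nc2nc(Nc3ccc(C#N)cc3)ncc2Cl)c(C)c1` is compound 3 after the same change: methyl in place of cyano on an aromatic carbon. The surroundings of the changed position read the same for both pairs, so this is the same change rather than merely the same kind.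

Going by the values given here, only one measured example of the change exists, so the expectation rests on it alone. Because the step from compound 1 to compound 2 was a number 0.43 log units higher from compound 1 to compound 2 (beyond the scatter), a step of similar size is expected here, namely a number 0.43 log units higher from compound 3 to compound 4 (beyond the scatter). Compound 4 is therefore estimated to give 1.54 in this assay, most likely between 1.2 and 1.9.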

Compound 4, partition coefficient: 1.72
The estimate for compound 4 lay 0.18 log units below the measured number, and the stated range covers the measured number.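

In this assay, methyl in place of cyano on an aromatic carbon gave a number 0.61 log units higher from compound 3 to compound 4 (beyond the scatter) on one core and a number 0.43 log units higher from compound 1 to compound 2 (beyond the scatter) on the other, so the change pointed the same way on both cores and each step lies beyond the usual scatter of repeated measurements. This supports carrying the direction of the change from the core of compound 1 to the core of compound 3, but two pairs are too few to show that it would hold on any further core in this series or to fix a dependable size for the step. No measurement shown here explains why the read-out moved with this swap.

The compounds shown leave open what other groups on the same aromatic carbon, such as an amine or a carboxylic acid, would do to this read-out. As far as these compounds go, the nitrile on the other aromatic ring stays in place in all four compounds, so the outcome of the same swap at that site also remains open.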